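Removing One Methoxy Group from a Dimethoxy Carbamate

This account rests on a few compounds, and the source may have more. Where it says the series, first, only, none or still open, it means among the compounds named here.

Compound 2, `COc1ccc(OC)c(NC(=O)Oc2cccc3cccnc23)c1`, stands in a functional assay for inhibition, with Rattus norvegicus as the target (on this read-out lower numbers stand for stronger inhibition and higher numbers for weaker inhibition), only at a limit: compound 2 gives < 10000 nM, which is a limit of the assay rather than a number. The two other values shown are limits as well. Compound 1, `COc1ccccc1NC(=O)Oc1ccc2ncccc2c1`, gives < 30000 nM in this assay, again a limit. Compound 3, `COc1ccc(NC(=O)Oc2cccc3ccc(C)nc23)cc1`, gives < 200 nM in this assay, also a limit. Compound 4, `COc1cccc(NC(=O)Oc2cccc3cccnc23)c1`, has not been measured; it differs from compound 2 by hydrogen in place of methoxy on an aromatic carbon. Going by the values given here, no step between measured compounds is known, so nothing shows how this change acts. One expects the step that the limit leaves unreadable from compound 2 to compound 4 to lie within the usual scatter, in no clear direction. For compound 4 the estimated value in this assay is 5000 nM, between 800 nM and 30000 nM.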

Compound 4, half-maximal inhibitory concentration: < 7000 nM
Compound 4: only a limit was reported; the forecaster's own chance of this, stated with the estimate: 60%; the middle value lies beyond the limit too.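

In this assay, compound 2 and compound 4 are each known only as a limit of the assay, and the step between them cannot be read. The compounds shown leave open what hydrogen in place of methoxy does to inhibition in this assay.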